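Swapping One Halogenated Ring for Another on Compound 3

This account rests on a few compounds, and the source may have more. Where it says the series, first, only, none or still open, it means among the compounds named here.

Of the compounds shown here, three sharing one core have been tested in a functional assay on PC-3 cells (Homo sapiens) for inhibition, read by MTT assay, with a stated time of 72 h; on this read-out lower numbers stand for stronger inhibition and higher numbers for weaker inhibition. Compound 1 `CCc1cccc(NC(=O)CSc2nc(Nc3ccccc3)c3ccccc3n2)c1` gives 11000 nM, compound 2 `O=C(CSc1nc(Nc2ccccc2)c2ccccc2n1)Nc1ccc(Br)cc1` gives 8450 nM, and compound 3 `C=CC(=O)Nc1cccc(NC(=O)CSc2nc(Nc3ccccc3F)c3ccccc3n2)c1` gives 9340 nM. Among the measured compounds shown here, the only single-place step among them, a 1.3-fold lower number from compound 1 to compound 2 (0.11 log units; within the scatter), lies within the scatter, and all three numbers sit within the scatter of one another, so compound 3 stands neither apart from nor ordered against the other two. Compound 4 `C=CC(=O)Nc1cccc(NC(=O)CSc2nc(Nc3ccc(Cl)cc3)c3ccccc3n2)c1` differs from compound 3 by 4-chlorophenyl in place of 2-fluorophenyl on a nitrogen on an aromatic ring. For the measured compounds named here, no measured step touches this nitrogen; the step from compound 1 to compound 2 changed a ring on the amide-type nitrogen instead and moved little. The expected step is therefore small, a 1.0-fold lower number from compound 3 to compound 4 (0.02 log units; within the scatter), with no set direction. Compound 4 is expected to give 9000 nM, within 3000 nM to 27000 nM.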

Compound 4, half-maximal inhibitory concentration: 10800 nM
Compound 4: middle estimate off by 1.2-fold (0.08 log units), on the low side, within the range that was stated.
By their numbers in this assay, from the lowest: compounds 2, 3, 4 and 1 (each within the scatter of the next).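

Replacing 2-fluorophenyl with 4-chlorophenyl on this nitrogen gives the first step seen at this position, a 1.2-fold higher number from compound 3 to compound 4 (0.06 log units; within the scatter), in this assay. The ring can therefore change both its halogen and where that halogen sits, with no change that this assay can distinguish from scatter. Nothing available here explains this result.

On these data alone, whether this position tolerates every change remains open, as both rings compared here carry a single halogen. An amine or a carboxylic acid on this ring could still shift the number, in either direction or not at all.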